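Replacing a lactam with a thiourea on the fused core

A few compounds are considered here, and "the series" means these few. Any claim that something is new, unique, unknown or untested is made for them only; others in the source may bear on it.

Measured compounds:
compound 1, `Cc1noc(NS(=O)(=O)c2cccc3c(N4CCCCC4=O)cccc23)c1C` — 270 nM
compound 2, `Cc1noc(NS(=O)(=O)c2ccc(NC(=O)Nc3ccccc3)cc2)c1C` — 38000 nM

In an assay on VSM-A10 cells for antagonist activity at Endothelin-1 receptor (Rattus norvegicus) (a lower number here means a stronger inhibitor, a higher number a weaker inhibitor), compound 1 gives 270 nM, the lowest of the two numbers recorded. Compound 2, which carries a different sulfonamide core, gives 38000 nM in this assay, a far higher number than compound 1, and the gap lies well beyond the scatter of repeated measurements.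

The untested compound 3, `Cc1noc(NS(=O)(=O)c2cccc3c(N/C(S)=N/c4ccccc4)cccc23)c1C`, keeps the fused core of compound 1 and alters a single substituent: a group of 10 heavy atoms (7 carbon, 2 nitrogen, 1 sulfur; one six-membered aromatic ring of carbon only) in place of a group of 7 heavy atoms (5 carbon, 1 nitrogen, 1 oxygen; one six-membered non-aromatic ring with 1 hetero atom), on an aromatic carbon. The group that leaves has no hydrogen-bond donors and one acceptor; the group that enters brings two donors and one acceptor, and a six-membered aromatic ring of carbon only where a non-aromatic ring stood before. Among the measured compounds shown here, no measured pair shows this exact exchange, so its effect cannot be read from the recorded numbers; compound 2 shares only the aromatic ring of the entering group and differs in its core.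

Compound 3 is therefore expected to give about 500 nM in this assay, within 100 nM to 3000 nM, an estimated step of a 1.9-fold higher number from compound 1 to compound 3 (0.27 log units; within the scatter) that may well fall within the scatter.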

Compound 3, half-maximal inhibitory concentration: 150 nM
The estimate for compound 3 lay 3.3-fold (0.52 log units) above the measured number, and the stated range covers the measured number.
By their numbers in this assay, from the lowest: compounds 3 and 1 (each within the scatter of the next); then compound 2.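

In this assay, placing the group with the six-membered aromatic ring of carbon only on this aromatic carbon of the core, in place of 2-oxopiperidin-1-yl, gives a 1.8-fold lower number from compound 1 to compound 3 (0.26 log units; within the scatter). The two compounds therefore cannot be told apart in this assay, even though the entering group has more heavy atoms, contains sulfur, adds hydrogen-bond donors, and replaces a non-aromatic ring with an aromatic one, so this position tolerates both of these quite different groups on the shared core. The data offer no measurement that accounts for this match between the two groups.

Because the single exchange alters the ring, the linking atoms and the donor count together, the compounds shown leave open which of these features, if any, matters at this position. On these data alone, it also remains open whether the same reading would hold with a cyclohexyl ring in place of the aromatic ring, with oxygen in place of the sulfur, or with a small group such as a primary amine on this aromatic carbon.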